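The compounds below may be only part of what the source reports. "The series", "measured", "known", "first", "only" and "open" are said of these compounds alone.

In a functional assay on PC-3 cells (Homo sapiens) for inhibition, read by sulforhodamine B assay, with a stated time of 48 h (on this read-out higher numbers stand for weaker inhibition of growth and lower numbers for stronger inhibition of growth), compound 1 (`O=C(Cc1csc2nc(-c3ccc(Br)cc3)cn12)N/N=C/c1ccccc1`) gives 20400 nM, and compound 2 (`O=C(Cc1csc2nc(-c3ccc(Br)cc3)cn12)N/N=C/c1ccccc1O`) gives 4270 nM. Compound 2 therefore holds the lower of the two numbers, which makes it the stronger inhibitor of growth of this pair. Compound 3 (`O=C(Cc1csc2nc(-c3ccc(Br)cc3)cn12)N/N=C/c1ccc(O)cc1`) has the same atoms as compound 2, but the hydroxy group sits elsewhere on the aromatic ring: 4-hydroxyphenyl in place of 2-hydroxyphenyl on a carbon with a double bond to nitrogen. For the measured compounds named here, only one measured step bears on this change, the modest gain seen when the hydroxy group was added, a 4.8-fold lower number from compound 1 to compound 2 (0.68 log units; beyond the scatter). Going by the values given here, no measured pair shows what happens when the hydroxy group changes place, so some of that gain may be lost or all of it kept. A slight lean to a higher number, within the usual scatter, is expected, and the estimated step is a 1.5-fold higher number from compound 2 to compound 3 (0.18 log units; within the scatter). Compound 3 is expected to give about 6500 nM, with an estimated range of 2500 nM to 17000 nM.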

Compound 3, concentration for 50% growth inhibition: > 10 nM
Compound 3 was reported as a limit (the forecaster's own chance of this, stated with the estimate: 5%); the middle value lies beyond the limit too.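

In this assay compound 3 gives > 10 nM, which is a limit and not a number. The steps from compound 1 and from compound 2 to compound 3 therefore cannot be read. From the compounds shown here alone, whether 4-hydroxyphenyl in place of 2-hydroxyphenyl changes growth inhibition stays open.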